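Adding a methoxy to the aryl group on the shared core

The compounds below may be only part of what the source reports. "The series", "measured", "known", "first", "only" and "open" are said of these compounds alone.

Measured compounds in a functional assay on HeLa cells (Homo sapiens) for cytotoxicity, read by WST assay, with a stated time of 48 h; a higher number here means a weaker inhibitor, a lower number a stronger inhibitor:
compound 1, `Cc1ccc(/C=C/C[C@H]2C[C@@H]([C@@H](O)c3ccccc3)CO[C@@H]2c2ccccc2)cc1C`, 10000 nM
compound 2, `COc1cccc([C@H]2OC[C@H]([C@@H](O)c3ccc(OC)c(OC)c3)C[C@@H]2C/C=C/c2ccc(OC)c(OC)c2)c1`, 21800 nM
compound 3, `COc1cccc([C@@H]2OC[C@H]([C@@H](O)c3ccc(OC)c(OC)c3)C[C@H]2C/C=C/c2ccc(OC)c(OC)c2)c1`, 30100 nM

Among these three numbers compound 2 stands second highest. Its nearest neighbour is compound 3, reached by a 1.4-fold higher number from compound 2 to compound 3 (0.14 log units; within the scatter), a step that lies within the scatter and that, because of the fact that compounds 2 and 3 differ only in the configuration as drawn, involves no change of substituent at all. Compound 1 gives a lower number than compound 2, and that gap lies beyond the scatter; the two structures differ in several places at once, so this pair offers no single isolated change.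

The unmeasured compound 4, `COc1ccc(/C=C/C[C@H]2C[C@@H]([C@@H](O)c3ccc(OC)c(OC)c3)CO[C@@H]2c2ccc(OC)c(OC)c2)cc1OC`, is reached from compound 2 by the change (methoxy in place of hydrogen on an aromatic carbon), which reads, cut one bond further out, as 3-methoxyphenyl to 3,4-dimethoxyphenyl. No measured step changes a methoxy for hydrogen on an aromatic ring, so none of the steps shown bears on this change. Among the compounds with values here, with no precedent, the expected step of no change at the digits printed from compound 2 to compound 4 (within the scatter) is set at none beyond the scatter. Compound 4 is therefore estimated at 21800 nM in this assay, with a range from 8000 nM to 55000 nM.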

Compound 4, half-maximal inhibitory concentration: 23800 nM
The estimate for compound 4 lay 1.1-fold (0.04 log units) below the measured number; the measured number falls inside the stated range.
By their numbers in this assay, from the lowest: compound 1; then compounds 2, 4 and 3 (each within the scatter of the next).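

In this assay, within the data shown here, the exchange of hydrogen for methoxy on an aromatic carbon shows a 1.1-fold higher number from compound 2 to compound 4 (0.04 log units; within the scatter) and so gives the first direct reading of this change, where 3-methoxyphenyl and 3,4-dimethoxyphenyl cannot be told apart. A methoxy at this position, ortho to a methoxy group and para to a large group, therefore moves the number by no more than the scatter, although this rests on a single pair of compounds and claims nothing for other positions. Nothing available explains why the number stays within the scatter after this exchange.

As far as these compounds go, whether an ethoxy, an amine or a carboxylic acid at this same position would give a step beyond the scatter remains open, as does whether a methoxy placed on one of the other aromatic rings of the shared core would behave in the same way. Compound 1 differs from compound 2 in several places at once, so the compounds shown also leave open which of those differences goes with its lower number.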